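A few compounds are considered here, and "the series" means these few. Any claim that something is new, unique, unknown or untested is made for them only; others in the source may bear on it.

Within the data shown here, compound 2 `N#Cc1ccc(/C=C2\Cc3cc(O)ccc3C2=O)cc1` gives 316 nM in an assay on isolated protein for inhibition of Amine oxidase [flavin-containing] B (Homo sapiens), read by fluorescence and spectrophotometry, with a stated time of 20 min (a higher number here means a weaker inhibitor, a lower number a stronger inhibitor), the highest of the two numbers so far; compound 1 `O=C1/C(=C/c2ccc(F)cc2)Cc2cc(O)ccc21` gives 47 nM in this assay. Among the measured compounds shown here, the one step measured, a 6.7-fold higher number from compound 1 to compound 2 (0.83 log units; beyond the scatter), shows that exchanging the group on this aromatic carbon moves the number by a modest amount. Compound 3 `CN(C)c1ccc(/C=C2\Cc3cc(O)ccc3C2=O)cc1` carries dimethylamino in place of cyano on an aromatic carbon. For the measured compounds named here, only the step from compound 1 to compound 2 bears on this change, and it concerns a different entering group, so direction is uncertain; a step of similar size is plausible. Compound 3 is estimated at 120 nM, range 30 nM to 500 nM, implying an expected 2.6-fold lower number from compound 2 to compound 3 (0.42 log units; beyond the scatter).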

Compound 3, half-maximal inhibitory concentration: 768 nM
Compound 3: the middle estimate sits 6.4-fold (0.81 log units) below what was measured; measured number above the stated range.
By their numbers in this assay, from the lowest: compound 1; then compound 2; then compound 3.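

At this position, on an aromatic carbon para to a large group, dimethylamino in this assay does not recover what the nitrile lost: the number rises again (a 2.4-fold higher number from compound 2 to compound 3 (0.39 log units; beyond the scatter)), and the full span from fluoro is large (a 16-fold higher number from compound 1 to compound 3 (1.21 log units; beyond the scatter)). Fluoro keeps the lowest number of the three, with both other groups clearly separated from it. No measurement on hand accounts for this order. Open, going by these compounds, is where a chlorine, a methoxy group or plain hydrogen on this carbon would fall relative to compound 1, and whether a primary amine would track compound 3.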